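Acetylphenyl in place of thiophene at the aryl position

The compounds below may be only part of what the source reports. "The series", "measured", "known", "first", "only" and "open" are said of these compounds alone.

Measured so far in a functional assay on SNB-19 cells (Homo sapiens) for inhibition, read by sulforhodamine B assay, with a stated time of 48 h, tested at 10 uM; a lower number here means less inhibition, a higher number more inhibition at the concentration tested (going by the name of the read-out):
compound 1 `COc1ccc(-c2cn3ccnc3c(-c3ccc4ncn(C5CCCCC5)c4c3)n2)cc1` — 68.4%
compound 2 `c1cn2cc(-c3ccsc3)nc(-c3ccc4ncn(C5CCCCC5)c4c3)c2n1` — 0.39%

Compound 2 stands lowest of the two numbers in this assay; its nearest neighbour is compound 1, whose number is higher beyond the scatter. Among the compounds with values here, the one measured step, a number 68 percentage points lower from compound 1 to compound 2 (beyond the scatter), is large and runs downward when thiophen-3-yl takes the place of 4-methoxyphenyl.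

Compound 3 `CC(=O)c1ccc(-c2cn3ccnc3c(-c3ccc4ncn(C5CCCCC5)c4c3)n2)cc1` differs from compound 2 by 4-acetylphenyl in place of thiophen-3-yl on an aromatic carbon. Within the data shown here, the only step that bears on this is a number 68 percentage points lower from compound 1 to compound 2 (beyond the scatter), where a six-membered aromatic ring of carbon only gave way to a five-membered ring with one hetero atom and the number fell sharply. On these data alone, the change to compound 3 runs the opposite way, restoring a six-membered carbon ring, though now as 4-acetylphenyl rather than 4-methoxyphenyl; the acetyl group itself is untested here. A large upward step is therefore expected, a number 54.6 percentage points higher from compound 2 to compound 3 (beyond the scatter), with wide uncertainty. Compound 3 is estimated at 55%, with a range from 15% to 85%.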

Compound 3, a percentage reported as inhibition, at one concentration (the size of the read-out at that concentration, not a potency): 3.96%
Estimate against measurement, compound 3: 51 percentage points above; the measured number lies below the stated range.
By their numbers in this assay, from the lowest: compounds 2 and 3 (each within the scatter of the next); then compound 1.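

In this assay, a six-membered aromatic ring of carbon at this position does not carry the inhibition on its own: the change gives a number 3.6 percentage points higher from compound 2 to compound 3 (within the scatter) and leaves 4-acetylphenyl not separable from thiophen-3-yl. The group on that ring decides the outcome in this small set, since acetyl in place of methoxy gives a number 64.4 percentage points lower from compound 1 to compound 3 (beyond the scatter) with all else in the structure kept. Nothing at hand accounts for this difference between methoxy and acetyl.

Open, on these data alone, is whether methoxy is singular or one of several groups on the phenyl ring that give a higher number in this assay, which an ethoxy, a hydroxyl, an amine or a carboxylic acid there would help to settle. Also open, as far as these compounds go, is whether a thiophene bearing a methoxy group would recover the inhibition seen with compound 1.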